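Swapping a pyridine ring for an ester-bearing chain

The source may report more compounds than this note shows. Statements on the series, on what has been measured and on what is new or still open speak of the compounds shown alone.

Measured compounds:
Compound 1 `CC(C)(C)c1ccc(CCC(=O)Nc2ccc3c(c2)OCCO3)cc1`: 660 nM
Compound 2 `CC(C)(C)c1ccc(/C(=C/C(=O)Nc2ccc3c(c2)OCCO3)c2cccnc2)cc1`: 510 nM

Both compounds share a core and were tested in a functional assay on CHO cells for inhibition of transient receptor potential cation channel subfamily V member 1 (Homo sapiens); on this read-out lower numbers stand for stronger inhibition and higher numbers for weaker inhibition. In this assay compound 1 gives 660 nM and compound 2 gives 510 nM. The two values lie within the usual scatter of repeated measurements, so compound 2 stands alongside compound 1 rather than apart from it, and neither can be called the more potent of the pair.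

Compound 3 `CCOC(=O)CC/C(=C\C(=O)Nc1ccc2c(c1)OCCO2)c1ccc(C(C)(C)C)cc1` has not yet been measured. It differs from compound 2 in one place: 2-(ethoxycarbonyl)ethyl in place of pyridin-3-yl on a double-bonded chain carbon bound to an aromatic carbon and a double-bonded chain carbon. Among the compounds with values here, no step between two measured compounds describes a change of this kind, so there is no measured precedent to lean on. The change is sizeable in nature, an aromatic ring giving way to an open chain carrying an ester, and the expectation is a modest move in this assay, if any, leaning towards a somewhat higher number rather than a lower one.

Compound 3 is therefore estimated at 800 nM, with a range from 250 nM to 2500 nM, which means an expected step of a 1.6-fold higher number from compound 2 to compound 3 (0.20 log units; within the scatter).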

Compound 3, half-maximal inhibitory concentration: 290 nM
Beside the measured number, compound 3's estimate is 2.8-fold (0.44 log units) above it; the measured number falls inside the stated range.
By their numbers in this assay, from the lowest: compounds 3, 2 and 1 (each within the scatter of the next, the first and the last beyond it).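

In this assay, putting 2-(ethoxycarbonyl)ethyl in place of pyridin-3-yl on a double-bonded chain carbon bound to an aromatic carbon and a double-bonded chain carbon comes with a 1.8-fold lower number from compound 2 to compound 3 (0.25 log units; within the scatter), so the two compounds read as level. For this pair, then, the six-membered aromatic ring is not required at this position to keep the number within the scatter: an open chain with no ring, carrying an ester, does as well, although the two groups share little beyond their similar size in heavy atoms. No measurement at hand explains why two such different groups read alike.

The compounds shown leave open which part of the new chain counts, since a plain propyl chain would test the chain without its ester, and a carboxylic acid in place of the ethyl ester would test the role of the ester's ethyl group. Also open, from the compounds shown here alone, is how much room this position offers, which a longer chain or a chain ending in an amine would probe, and whether any such group would move the number in this assay beyond the scatter.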